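Cytotoxicity notes: ethyl to isopropyl on the shared core

This account rests on a few compounds, and the source may have more. Where it says the series, first, only, none or still open, it means among the compounds named here.

In an ADME assay on C1866 cells (Homo sapiens) for cytotoxicity, read by MTT assay, with a stated time of 72 h (a higher number here means that more compound is needed for the effect, a lower number that less compound is needed), compound 1 `CC(C)c1c(CC2CCCCC2)nc(SCC(=O)c2ccccc2)[nH]c1=O` gives 0.025 nM. Compound 2 `CCc1c(Cc2ccccc2)nc(SCC(=O)c2ccccc2)[nH]c1=O` gives 80.2 nM in this assay, the highest of the two numbers shown; its nearest neighbour is compound 1, at a far lower number, beyond the scatter. Compound 3 `CC(C)c1c(Cc2ccccc2)nc(SCC(=O)c2ccccc2)[nH]c1=O` awaits measurement in this assay. It differs from compound 2 by methyl in place of hydrogen on a saturated chain carbon bound to an aromatic carbon and a saturated chain carbon; cut one bond further out, ethyl becomes isopropyl. Among the measured compounds shown here, no measured pair covers this change alone, and compound 1 differs from compound 3 in a second place, so a lowering of the number is expected, of uncertain size. Compound 3 is estimated in this assay at 3 nM, within 0.1 nM to 60 nM. The expected step is a 27-fold lower number from compound 2 to compound 3 (1.43 log units; beyond the scatter).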

Compound 3, half-maximal effective concentration: 14 nM
Beside the measured number, compound 3's estimate is 4.7-fold (0.67 log units) below it; measured number inside the range.
By their numbers in this assay, from the lowest: compound 1; then compound 3; then compound 2.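

In this assay, ethyl to isopropyl on its own gives a 5.7-fold lower number from compound 2 to compound 3 (0.76 log units; beyond the scatter), a modest step at this position. With isopropyl held in place, phenyl in place of cyclohexyl gives a 560-fold higher number from compound 1 to compound 3 (2.75 log units; beyond the scatter), a much larger step, so most of the distance to the lowest number in this series lies with the cyclohexyl group. No measured evidence on the cause of either step is available. On these data alone, whether a tert-butyl group or a longer chain in place of isopropyl lowers the number further remains open, as does the size of the ethyl to isopropyl step with cyclohexyl present.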